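Aryl amines on a shared core: pyridin-3-yl variant

This account rests on a few compounds, and the source may have more. Where it says the series, first, only, none or still open, it means among the compounds named here.

Three compounds share one core and differ only in the aryl group on the amine nitrogen. Compound 1 `Cc1sc2c(Nc3ccc(C#N)cc3)cccc2c1C` gives 79.6% in a functional assay for inhibition, with a stated time of 2 h, tested at 0.250 g/L (on this read-out higher numbers stand for more inhibition at the one concentration tested (going by the name of the read-out) and lower numbers for less inhibition), and compound 3 `COc1cccc(Nc2cccc3c(C)c(C)sc23)c1` gives 84.8% in this assay. Compound 2 `Cc1sc2c(Nc3ccccn3)cccc2c1C` gives 47.2% in this assay, the lowest of the three numbers and beyond the scatter from both compound 1 and compound 3. Compound 4 `Cc1sc2c(Nc3cccnc3)cccc2c1C` is not yet measured. It differs from compound 2 by pyridin-3-yl in place of pyridin-2-yl on a nitrogen on an aromatic ring. For the measured compounds named here, no measured pair isolates this change, so the direction rests only on the two other aryl amines, which both sit higher than compound 2. The estimated step in this assay is a number 12.8 percentage points higher from compound 2 to compound 4 (beyond the scatter), upward but uncertain and possibly still within the scatter. Compound 4 is expected to give 60% in this assay, with a range of 35% to 85%.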

Compound 4, a percentage reported as inhibition, at one concentration (the size of the read-out at that concentration, not a potency): 86.2%
Compound 4: the middle estimate sits 26.2 percentage points below what was measured; the measured number lies above the stated range.
By their numbers in this assay, from the lowest: compound 2; then compounds 1, 3 and 4 (each within the scatter of the next).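

In this assay, the position of the ring nitrogen alone matters: with the same atoms joined differently, pyridin-3-yl in place of pyridin-2-yl gives a number 39 percentage points higher from compound 2 to compound 4 (beyond the scatter). The low number of compound 2 therefore belongs to pyridin-2-yl and not to every pyridinyl group on this nitrogen, and compound 4 sits with compounds 1 and 3, each within the scatter of the next. Nothing available explains the difference between the two groups. Still open, from the compounds shown here alone, is whether a carboxylic acid or an amine on the aryl group would hold the number at this level.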